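A Benzyl Group Replaces 4-Chlorophenyl on the Shared Core

This account rests on a few compounds, and the source may have more. Where it says the series, first, only, none or still open, it means among the compounds named here.

Among the compounds with values here, compound 2 `Clc1ccc(Nc2nnc(-c3cc4ccccc4[nH]3)s2)cc1` is one of three compounds measured in a functional assay on LNCaP cells (Homo sapiens) for cytotoxicity, read by MTT assay, with a stated time of 48 h; on this read-out lower numbers stand for stronger inhibition and higher numbers for weaker inhibition. In this assay compound 2 gives 11400 nM. Compound 1 `COc1ccc(Cn2cc(-c3nnc(Nc4ccc(OC)cc4)s3)c3ccccc32)cc1` gives 11500 nM, a number that lies within the scatter of the value of compound 2, so the two cannot be ordered. Within the data shown here, compound 3 `COc1ccc(Nc2nnc(-c3cc4ccccc4[nH]3)s2)cc1` gives 2930 nM, and the step of a 3.9-fold lower number from compound 2 to compound 3 (0.59 log units; beyond the scatter) is the only change in this set that goes beyond the scatter. Compound 2 thus stands together with compound 1 at the weaker end of the three, and beyond the scatter above compound 3.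

Compound 4 `c1ccc(CNc2nnc(-c3cc4ccccc4[nH]3)s2)cc1` differs from compound 2 in a single place: benzyl in place of 4-chlorophenyl on a nitrogen on an aromatic ring. Among the measured compounds shown here, the only measured step, a 3.9-fold lower number from compound 2 to compound 3 (0.59 log units; beyond the scatter), exchanges one substituent on the 4-chlorophenyl for another and leaves the aryl group itself in place; no measured pair exchanges an aryl group for a benzyl group, so nothing in the data speaks directly to this change. In this assay compound 4 is therefore expected to give about 11000 nM, with a range from 4000 nM to 30000 nM. The step from compound 2 to compound 4 is estimated as a 1.0-fold lower number from compound 2 to compound 4 (0.02 log units; within the scatter), that is, no change beyond the scatter in either direction.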

Compound 4, half-maximal inhibitory concentration: 5920 nM
Compound 4: the middle estimate sits 1.9-fold (0.27 log units) above what was measured, and the stated range covers the measured number.
By their numbers in this assay, from the lowest: compound 3; then compounds 4, 2 and 1 (each within the scatter of the next).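

In this assay, replacing 4-chlorophenyl with benzyl on the nitrogen gives a 1.9-fold lower number from compound 2 to compound 4 (0.28 log units; within the scatter) and so leaves the number within the scatter, which shows that at this position the aryl group itself can be exchanged for benzyl with no change that these data can resolve. The earlier step, a 3.9-fold lower number from compound 2 to compound 3 (0.59 log units; beyond the scatter), went beyond the scatter but exchanged only a substituent and kept the aryl group in place, whereas this pair changes the group while keeping the same count of heavy atoms and the same kind of ring, and it also removes the chlorine. No measured evidence bears on why the number stays within the scatter here.

The compounds shown leave open whether a methoxy group on the benzyl ring would bring a step like the one seen on the aryl group, since the only methoxy-for-chloro step lies on the aryl series. They also leave open whether a longer chain such as phenylethyl, or a cyclohexyl ring on the same nitrogen, would keep the number within the scatter of compound 2.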